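Ring swap at the amide carbonyl of compound 3

The compounds below may be only part of what the source reports. "The series", "measured", "known", "first", "only" and "open" are said of these compounds alone.

Three compounds share a core and were tested in an assay on cells with Cystic fibrosis transmembrane conductance regulator variant F508del (Homo sapiens) as the target, read by voltage clamp, with a stated time of 24 h, in the presence of a further agent that is not named here; a higher number here means that more compound is needed for the effect, a lower number that less compound is needed. Compound 1 `COc1ccc(C(F)(F)F)cc1CO[C@H]1[C@H](C(C)(C)C)[C@@H](C(=O)O)N(C(=O)C2CCCCC2)[C@H]1c1ccccc1` gives 173 nM. Compound 2 `COc1ncc(C(F)(F)F)cc1CO[C@H]1[C@H](C(C)(C)C)[C@@H](C(=O)O)N(C(=O)C2CCCCC2)[C@H]1c1ccccc1` gives 150 nM, and the step of a 1.2-fold lower number from compound 1 to compound 2 (0.06 log units; within the scatter) lies within the scatter. Compound 3 `COc1ncc(C(F)(F)F)cc1CO[C@H]1[C@H](C(C)(C)C)[C@@H](C(=O)O)N(C(=O)OC(C)C)[C@H]1c1ccccc1` gives 137 nM; this is the lowest of the three numbers, yet the step of a 1.1-fold lower number from compound 2 to compound 3 (0.04 log units; within the scatter) is within the scatter, and its gap to compound 1 is within the scatter as well, so the three compounds cannot be ranked on these data.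

Compound 4 `COc1ncc(C(F)(F)F)cc1CO[C@H]1[C@H](C(C)(C)C)[C@@H](C(=O)O)N(C(=O)[C@H]2CCCCO2)[C@H]1c1ccccc1` differs from compound 3 in one place: oxan-2-yl in place of isopropoxy on a carbonyl carbon. The step that bears most directly on this change is a 1.1-fold lower number from compound 2 to compound 3 (0.04 log units; within the scatter), where a six-membered carbon ring on the same carbonyl carbon was exchanged for isopropoxy without any effect beyond the scatter. Compound 4 brings a six-membered ring back to that position, now with one oxygen in the ring, so the closest comparison is compound 2 with 150 nM.

On this basis the step of a 1.1-fold higher number from compound 3 to compound 4 (0.04 log units; within the scatter) is expected to stay within the scatter. The estimate for compound 4 in this assay is 150 nM, with a range from 70 nM to 320 nM.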

Compound 4, half-maximal effective concentration: 346 nM
Compound 4: the middle estimate sits 2.3-fold (0.36 log units) below what was measured; measured number outside the range, above it.
By their numbers in this assay, from the lowest: compounds 3, 2, 1 and 4 (each within the scatter of the next, the first and the last beyond it).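

In this assay, cyclohexyl and isopropoxy on this carbonyl carbon could not be told apart, but oxan-2-yl in place of isopropoxy gives a 2.5-fold higher number from compound 3 to compound 4 (0.40 log units; beyond the scatter), so this position is not indifferent to every group placed on it. The ring comparison adds a second point: oxan-2-yl in place of cyclohexyl gives a 2.3-fold higher number from compound 2 to compound 4 (0.36 log units; beyond the scatter), so a six-membered ring here does not by itself guarantee a number like that of compound 2, and the two rings differ in the ring oxygen and in the defined stereocentre that oxan-2-yl carries. Nothing available on these compounds accounts for the modest rise seen with compound 4.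

The compounds shown do not separate the contribution of the ring oxygen from that of the stereocentre, and the opposite stereoisomer of the oxan-2-yl group would speak to the second of these. An oxan-4-yl group, which has a ring oxygen but no stereocentre, or a piperidin-2-yl group, which has a ring nitrogen in place of that oxygen, would test on this same carbonyl carbon how far the result depends on the identity of the ring atom.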